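The compounds below may be only part of what the source reports. "The series", "measured", "known", "first", "only" and "open" are said of these compounds alone.

Measured compounds:
Compound 1 `Cc1ccccc1NS(=O)(=O)c1ccc(N2CCNC2=O)cc1` gives 200 nM in a functional assay on HT-29 cells (Homo sapiens) for antiproliferative activity, read by sulforhodamine B assay, with a stated time of 48 h; on this read-out higher numbers stand for weaker inhibition and lower numbers for stronger inhibition.
Compound 3 `Cc1cccc(NS(=O)(=O)c2ccc(N3CCNC3=O)cc2)c1C` gives 190 nM in this assay.
Compound 2 `O=C1NCCN1c1ccc(S(=O)(=O)Nc2ccc(C3CCCCC3)cc2)cc1` gives only a limit, > 1000 nM, in this assay.

Compound 2 stands apart from the other two measured compounds: its value is a limit of the assay and not a number, so only the limit of > 1000 nM in this assay, at which 1 of the 3 values shown sits, is known of it, while compound 1 and compound 3 both sit well inside the measured range. Within the data shown here, the one step measured between compounds that differ in a single place, a 1.1-fold lower number from compound 1 to compound 3 (0.02 log units; within the scatter), concerns a methyl in place of hydrogen on an aromatic carbon and is within the scatter; it does not involve the part of the molecule changed here and gives no direct guide.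

Compound 4 `CCCCc1ccc(NS(=O)(=O)c2ccc(N3CCNC3=O)cc2)cc1` differs from compound 2 in one place: butyl in place of cyclohexyl on an aromatic carbon. With compound 2 known only as a limit, the size of the step cannot be judged from a measured pair. The expectation is that compound 4 in this assay moves toward the region of compound 1 and compound 3, with an at least 1.2-fold lower number from compound 2 to compound 4 (0.09 log units; that floor lies within the scatter) as the estimated step. Compound 4 is therefore expected at about 800 nM, in the range 200 nM to 3000 nM, with a real chance that only a limit is reported again.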

Compound 4, half-maximal inhibitory concentration: 610 nM
Beside the measured number, compound 4's estimate is 1.3-fold (0.12 log units) above it, within the range that was stated.
By their numbers in this assay, from the lowest: compounds 3 and 1 (each within the scatter of the next); then compound 4. At a limit, above all of these: compound 2.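

Placing butyl instead of cyclohexyl on this aromatic carbon, para to a large group, gives an at least 1.6-fold lower number from compound 2 to compound 4 (0.21 log units; that floor lies within the scatter) in this assay. Among these compounds, this is the first measured comparison at this position, and it shows that a change here, from a six-membered non-aromatic ring to an open chain, can turn a limit into a number, though that alone does not establish a gain beyond the scatter. The value of compound 2 is a limit and not a number, and because of this the step is only a floor, with its true size unknown: the limit of > 1000 nM in this assay, at which 1 of the 4 values shown sits.

As far as these compounds go, it remains open how a shorter chain such as ethyl, a longer chain such as hexyl, or a smaller ring such as cyclopentyl would read on this same aromatic carbon in this assay. Also open is whether an amine or a carboxylic acid in this place would be tolerated, and the compounds shown give no guide to how such a group would compare with butyl.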